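One Flipped Ring Stereocentre in a Growth Inhibitor

The compounds below may be only part of what the source reports. "The series", "measured", "known", "first", "only" and "open" are said of these compounds alone.

In a functional assay on OCI-Ly3 cells (Homo sapiens) for inhibition, read by CellTiter-Glo, with stated times of 48 h and 96 h (a lower number here means a stronger inhibitor of growth, a higher number a weaker inhibitor of growth), compound 1 `CC(C)[C@H](NC(=O)c1ccc(C(F)(F)F)cc1)C(=O)N1CCC[C@H]1C(=O)N[C@@H](CCCNC(=N)N)C(=O)CF` gives 120 nM, while compound 2 `CC(C)[C@H](NC(=O)OCc1ccccc1)C(=O)N1C[C@H](O)C[C@H]1C(=O)N[C@@H](CCCNC(=N)N)C(=O)CF` gives 290 nM. Compound 2 therefore has the higher number of the two, a gap beyond the scatter, and is the weaker growth inhibitor. Compound 3 `CC(C)[C@H](NC(=O)OCc1ccccc1)C(=O)N1C[C@@H](O)C[C@H]1C(=O)N[C@@H](CCCNC(=N)N)C(=O)CF` is its close relative: the two compounds have the same atoms and bonds; at least one stereo element is drawn with a configuration in one of them and without one in the other: 1 of 5 stereo elements differ; a stereocentre at a saturated ring carbon is drawn R in compound 2 and S in compound 3. A stereocentre at a saturated ring carbon is drawn R in compound 2 and S in compound 3. Among the measured compounds shown here, no measured pair shows what this change does, so only a modest weakening in this assay is expected, with the estimated step of a 1.6-fold higher number from compound 2 to compound 3 (0.19 log units; within the scatter). For compound 3, the estimated value is 450 nM, within a range of 130 nM to 1500 nM.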

Compound 3, concentration for 50% growth inhibition: 1070 nM
Estimate against measurement, compound 3: 2.4-fold (0.38 log units) below; the measured number falls inside the stated range.
By their numbers in this assay, from the lowest: compound 1; then compound 2; then compound 3.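

With atoms and bonds unchanged, the configuration at one saturated ring carbon accounts for the whole difference in this assay, giving a 3.7-fold higher number from compound 2 to compound 3 (0.57 log units; beyond the scatter). The earlier compounds shown here differ in more than one place and could not isolate this sensitivity to configuration at the ring carbon. One caution applies to this reading: the fact that one of compounds 2 and 3 is drawn with a defined configuration and the other without, at the place where they differ.

The compounds shown leave open whether this ring carbon needs its hydroxyl group at all. They also leave open how an amine or a methoxy group there would compare in either configuration.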